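The compounds below may be only part of what the source reports. "The series", "measured", "known", "first", "only" and "open" are said of these compounds alone.

Working notes on the series, read-out a physicochemical assay for solubility, in phosphate buffer, at pH 6.5; a higher number here means a more soluble compound, a lower number a less soluble compound. Two compounds on the shared core have results so far. Compound 1 `CNc1nc(NC(C)(C)C)c2sc(-c3ccc(C(F)(F)F)cc3)cc2n1` gives < 1.6 ug/mL, which is a limit of the assay and not a number. Among the measured compounds shown here, compound 2 `Nc1nc(NC2CCCNC2)c2sc(-c3ccc(C(F)(F)F)cc3)cc2n1` gives 125 ug/mL, the only true number available, so it has no second number to be ranked against. Its value does lie clear of the limit reported for compound 1.

Compound 3 `Nc1nc(N2CCC(N)CC2)c2sc(-c3ccc(C(F)(F)F)cc3)cc2n1` has the same atoms as compound 2, joined differently: 4-aminopiperidin-1-yl in place of (piperidin-3-yl)amino on an aromatic carbon. The new group, 4-aminopiperidin-1-yl, takes the place of (piperidin-3-yl)amino on the same aromatic carbon, next to the ring nitrogen. For the measured compounds named here, no measured step on this change exists, and compound 1 and compound 2 differ in more than one place. The expectation therefore rests on compound 2 at 125 ug/mL and on the shared atom content. The expected step, a 1.3-fold lower number from compound 2 to compound 3 (0.10 log units; within the scatter), is slightly downward and no larger than the usual scatter in this assay. For compound 3 the estimated value is 100 ug/mL, with an expected range from 30 ug/mL to 300 ug/mL.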

Compound 3, solubility: 134 ug/mL
The estimate for compound 3 lay 1.3-fold (0.13 log units) below the measured number; measured number inside the range.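

In this assay the series now holds a 1.1-fold higher number from compound 2 to compound 3 (0.03 log units; within the scatter) as its first step read at this position, on the aromatic carbon next to the ring nitrogen. The earlier compounds shown here could not show this, since compound 1 and compound 2 differ in more than one place; here 4-aminopiperidin-1-yl and (piperidin-3-yl)amino hold the same heavy atoms joined differently, and the two results cannot be told apart. Two true numbers now stand on the shared core, yet nothing at hand gives a reason why this rearrangement leaves the read-out within the scatter.

Going by these compounds, whether a group of a different kind at this position, such as a morpholine, an open-chain diamine or a carboxylic acid, would keep the result in the same place stays open. Compound 1 differs from compound 2 and compound 3 in more than one place, so the separate contributions of its groups remain unresolved.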